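Removal of the fluorophenyl arm in the T-type series

A few compounds are considered here, and "the series" means these few. Any claim that something is new, unique, unknown or untested is made for them only; others in the source may bear on it.

Three compounds sharing the core of compound 1 `CN(C)CCCCCSC1=Nc2ccccc2C(CC(=O)NCc2ccccc2)N1c1ccc(-c2ccc(F)cc2)cc1` have been measured in an assay on cells for inhibition of Voltage-dependent T-type calcium channel subunit alpha-1I (Homo sapiens), read by patch clamp, tested at 10 uM; a lower number here means less inhibition, a higher number more inhibition at the concentration tested (going by the name of the read-out). Compound 1 gives 66.7% and stands lowest of the three; compound 2 `O=C(CC1c2ccccc2N=C(SCCCCCN2CCCC2)N1c1ccc(-c2ccc(F)cc2)cc1)NCc1ccccc1` gives 68.2%, and compound 3 `O=C(CC1c2ccccc2N=C(SCCCCCN2CCCC2)N1c1ccc(-c2ccccc2)cc1)NCc1ccccc1` gives 92.7%. The two steps among them are a number 1.5 percentage points higher from compound 1 to compound 2 (within the scatter) and a number 24.5 percentage points higher from compound 2 to compound 3 (beyond the scatter). Compound 4 `CN(C)CCCCCSC1=Nc2ccccc2C(CC(=O)NCc2ccccc2)N1c1ccccc1` differs from compound 1 by hydrogen in place of 4-fluorophenyl on an aromatic carbon. For the measured compounds named here, no measured step removes the whole 4-fluorophenyl group; the nearest is the loss of fluoro alone from compound 2 to compound 3, which gave a modest rise in this assay, while exchanging the amine from compound 1 to compound 2 changed nothing beyond the scatter. The change to compound 4 is larger than either, and the direction of its effect is not predictable from the three values, so the expected step of a number 6.7 percentage points lower from compound 1 to compound 4 (within the scatter) is uncertain and could fall either side of no change. Compound 4 is estimated at 60%, with a range from 35% to 85%.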

Compound 4, a percentage reported as inhibition, at one concentration (the size of the read-out at that concentration, not a potency): 76%
Compound 4: the middle estimate sits 16 percentage points below what was measured; low and high end bracket the measured number.
By their numbers in this assay, from the lowest: compounds 1, 2 and 4 (each within the scatter of the next); then compound 3.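

In this assay, the whole 4-fluorophenyl group can leave this aromatic carbon, para to a large group, with a step of a number 9.3 percentage points higher from compound 1 to compound 4 (within the scatter), so on the dimethylamino compounds the number does not depend measurably on those 7 heavy atoms. The earlier compounds shown here showed only the loss of fluoro alone on the pyrrolidin-1-yl compounds, a number 24.5 percentage points higher from compound 2 to compound 3 (beyond the scatter), and left open whether the outer aromatic ring mattered at all. No measurement available here accounts for either step.

Open, from the compounds shown here alone, is whether hydrogen in place of 4-fluorophenyl behaves the same on the pyrrolidin-1-yl compounds, and whether phenyl on the dimethylamino compound repeats the rise seen with compound 3. Also open, going by these compounds, is how a small group such as chloro or methoxy at this carbon would compare with hydrogen.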